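Compound 3: 2-methoxyphenyl in place of 4-methoxyphenyl

The source may report more compounds than this note shows. Statements on the series, on what has been measured and on what is new or still open speak of the compounds shown alone.

Measured so far in a functional assay on HeLa cells (Homo sapiens) for cytotoxicity, read by WST assay, with a stated time of 48 h; a higher number here means a weaker inhibitor, a lower number a stronger inhibitor:
compound 1 `Oc1ccccc1/C=C/C[C@H]1C[C@@H]([C@@H](O)c2ccccc2)CO[C@@H]1c1ccccc1` gives 21800 nM
compound 2 `COc1ccc(/C=C/C[C@H]2C[C@@H]([C@@H](O)c3ccccc3)CO[C@@H]2c2ccccc2)cc1` gives 8300 nM

Of these two numbers, compound 2 holds the lower, with 8300 nM as its value. The next case is compound 3 `COc1ccccc1/C=C/C[C@H]1C[C@@H]([C@@H](O)c2ccccc2)CO[C@@H]1c1ccccc1` and its change is 2-methoxyphenyl in place of 4-methoxyphenyl on a double-bonded chain carbon bound to a double-bonded chain carbon on a double-bonded chain carbon bound to a double-bonded chain carbon. The two structures have the same atoms, joined differently.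

Going by the values given here, only one measured step bears on this: a 2.6-fold lower number from compound 1 to compound 2 (0.42 log units; beyond the scatter) is modest, yet it swaps a 2-hydroxyphenyl for a 4-methoxyphenyl and so alters two things at once. Among the compounds with values here, no measured pair isolates the move of the methoxy group alone. Compound 3 shares its methoxy with compound 2 and the number in its group name with the 2-hydroxyphenyl of compound 1, so a value near compound 2 and leaning slightly towards compound 1 seems likely. In this assay no step beyond the scatter is expected, and the estimated step is a 1.3-fold higher number from compound 2 to compound 3 (0.12 log units; within the scatter) in size. For compound 3 the estimated value is 11000 nM with an expected range from 5000 nM to 24000 nM around it.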

Compound 3, half-maximal inhibitory concentration: 14700 nM
Compound 3: middle estimate off by 1.3-fold (0.13 log units), on the low side; the range from low to high includes it.
By their numbers in this assay, from the lowest: compounds 2, 3 and 1 (each within the scatter of the next, the first and the last beyond it).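

In this assay, going by these compounds alone, the move from 4-methoxyphenyl to 2-methoxyphenyl gives a 1.8-fold higher number from compound 2 to compound 3 (0.25 log units; within the scatter), the first pair to isolate where the methoxy group sits on this ring. Capping the hydroxyl of the 2-hydroxyphenyl with a methyl group gives a 1.5-fold lower number from compound 1 to compound 3 (0.17 log units; within the scatter), so the two changes combined in the earlier step, a 2.6-fold lower number from compound 1 to compound 2 (0.42 log units; beyond the scatter), now stand apart, and neither alone goes beyond the scatter, although together they do. No measurement available here explains these numbers.

The compounds shown leave open whether any group on this ring can shift the number further than these small changes have, since the hydroxyl and methoxy groups are the only substituents tested and an amine or a carboxylic acid in their place would test a different kind of group. They also leave open whether a longer chain between the double bond and the shared core, or a change on its other phenyl groups, would matter more than anything done on this ring.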